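Alkoxy chain length on the shared biaryl acid series

The source may report more compounds than this note shows. Statements on the series, on what has been measured and on what is new or still open speak of the compounds shown alone.

Measured so far:
compound 1 `CCCOc1ccc(C)c(-c2cccc(COc3ccc(OCC(=O)O)c(F)c3)c2)c1`: 610 nM
compound 2 `Cc1ccc(OCC(C)C)cc1-c1cccc(COc2ccc(OCC(=O)O)c(F)c2)c1`: 1450 nM
compound 3 `COc1cccc(-c2cccc(COc3ccc(OCC(=O)O)c(F)c3)c2)c1`: 540 nM

All three were run in a functional assay on CHO cells for agonist activity at Free fatty acid receptor 1 (Homo sapiens), read by FLIPR and calcium flux; on this read-out lower numbers stand for an effect already at smaller amounts and higher numbers for an effect only at larger amounts of compound. Compound 1 and compound 3 give numbers that lie within the usual scatter of each other, so no order between them can be read; compound 2 stands apart from both. The difference between the cores of compound 1 and compound 3 is not broken down here. One single-point change is on record within the measured set: a 2.4-fold higher number from compound 1 to compound 2 (0.38 log units; beyond the scatter), the change being (methyl in place of hydrogen on a saturated chain carbon bound to two saturated chain carbons).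

Compound 4 `CCOc1cccc(-c2cccc(COc3ccc(OCC(=O)O)c(F)c3)c2)c1` has not yet been measured in this assay. It differs from compound 3 by methyl in place of hydrogen on a saturated chain carbon bound to an oxygen on an aromatic ring. This is the same kind of change as that between compound 1 and compound 2, but not the same: there the entering methyl sits on a saturated chain carbon bound to two saturated chain carbons, here on a saturated chain carbon bound to an oxygen on an aromatic ring. The recorded step, a 2.4-fold higher number from compound 1 to compound 2 (0.38 log units; beyond the scatter), was modest, and its surroundings differ from the present case.

A smaller step is expected here because compound 1 with its propoxy chain gives 610 nM while compound 3 with a methoxy gives 540 nM, numbers within the scatter of each other, which argues that lengthening this chain by one carbon moves the read-out little. The expected step is a 1.1-fold lower number from compound 3 to compound 4 (0.03 log units; within the scatter). Compound 4 is estimated at 500 nM, with a range from 200 nM to 1300 nM.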

Compound 4, half-maximal effective concentration: 480 nM
Estimate against measurement, compound 4: 1.0-fold (0.02 log units) above; the measured number falls inside the stated range.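

In this assay, methyl in place of hydrogen on a saturated chain carbon bound to an oxygen on an aromatic ring gives a 1.1-fold lower number from compound 3 to compound 4 (0.05 log units; within the scatter), so going from methoxy to ethoxy on this core leaves the read-out within the usual scatter. Set beside the earlier step, this kind of change does not carry from one core to another as a fixed increment: the same change on two cores in this assay, a 2.4-fold higher number (0.38 log units; beyond the scatter) from compound 1 to compound 2 and a 1.1-fold lower number (0.05 log units; within the scatter) from compound 3 to compound 4, 2.7-fold (0.43 log units) apart, beyond the scatter of two such steps

This does not show whether the gap belongs to the core or to the carbon taking the methyl, as the two steps differ in both, and two pairs of compounds set no rule for the series.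

Still open, going by these compounds, is how the read-out runs along a chain series on a single core, as the propoxy chain and the branched chain of compound 2 stand only on the core of compound 1, and ethoxy only on the core of compound 3. A longer chain such as butoxy or hexyloxy in place of ethoxy, or a 2-methoxyethoxy group, would show whether the flat step from methoxy to ethoxy continues on that core.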